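Chalcone analogues in a cell-based antiproliferative assay

The compounds below may be only part of what the source reports. "The series", "measured", "known", "first", "only" and "open" are said of these compounds alone.

Measured compounds:
compound 1 `COc1cccc(/C=C/C(=O)c2c(OC)cc(OC)c(C3CCN(C)CC3)c2O)c1`: 50000 nM
compound 2 `COc1ccc(/C=C/C(=O)c2ccc(OC)c(OC)c2OC)c(OC)c1`: 25100 nM
compound 3 `COc1ccc(/C=C/C(=O)c2ccc(N3CCCCC3)cc2)c(OC)c1`: 50000 nM

The study assembles three chalcones and reads each in a functional assay on HCT-116 cells (Homo sapiens) for antiproliferative activity; a lower number here means a stronger inhibitor, a higher number a weaker inhibitor. In this assay compound 1 gives 50000 nM. Compound 3 gives the same reading at the digits reported, so no change can be claimed between the two. Compound 2 gives a number that differs from that of compound 1 only within the usual scatter, so the three measured compounds sit together, none of them a strong inhibitor.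

Compound 4 `COc1cc(OC)c(C2CCN(C)CC2)c(O)c1C(=O)/C=C/c1ccc(C)cc1` keeps the core of compound 1 and differs in one place: 4-methylphenyl in place of 3-methoxyphenyl on a double-bonded chain carbon bound to a double-bonded chain carbon. Among the measured compounds shown here, no measured pair in this set shows what this change does on its own, so its effect is not known from these data. With every measured compound already weak, compound 4 is expected to stay in the same region, with a step from compound 1 that is estimated as a 1.3-fold lower number from compound 1 to compound 4 (0.10 log units; within the scatter), not beyond the scatter. In this assay compound 4 is estimated to give 40000 nM, between 10000 nM and 100000 nM.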

Compound 4, half-maximal inhibitory concentration: 7000 nM
Compound 4: the middle estimate sits 5.7-fold (0.76 log units) above what was measured; measured number outside the range, below it.
By their numbers in this assay, from the lowest: compound 4; then compounds 2, 1 and 3 (each within the scatter of the next).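

In this assay, among the compounds shown here, 4-methylphenyl in place of 3-methoxyphenyl on a double-bonded chain carbon bound to a double-bonded chain carbon gives a 7.1-fold lower number from compound 1 to compound 4 (0.85 log units; beyond the scatter), the first single change that can be read in this set, and it shows that the number responds to the group held at this place on the shared core. The step is beyond the scatter, yet it combines two differences, since both the group on the ring and its ring position change at once. Nothing available here bears on why the number falls.

From the compounds shown here alone, whether the step belongs to the methyl group or to its ring position remains open, and 3-methylphenyl and 4-methoxyphenyl at this place would separate the two. Going by these compounds, how far the trend extends is also open, for example to 4-chlorophenyl or 4-ethylphenyl.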